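The compounds below may be only part of what the source reports. "The series", "measured", "known", "first", "only" and "open" are said of these compounds alone.

Measured so far in a functional assay on the whole organism for inhibition, with Cavia porcellus as the target; a lower number here means that less compound is needed, a higher number that more compound is needed for the effect:
Compound 1 `CCOC(=O)c1cn2c(Br)cncc2n1`: 52 nM
Compound 2 `NC(=O)c1cn2c(Br)cncc2n1`: 38 nM

Compound 2 and compound 1 lie within the scatter of each other, so the two values set neither compound apart. The next step leads to compound 3 `N#Cc1cn2c(Br)cncc2n1`, which carries cyano in place of carbamoyl on an aromatic carbon. Among the measured compounds shown here, only one measured step bears on this change: a 1.4-fold lower number from compound 1 to compound 2 (0.14 log units; within the scatter), amino in place of ethoxy on a carbonyl carbon. That step stayed within the scatter, but it did not remove the carbonyl, so it is only an indirect guide. For the measured compounds named here, no measured step shows what replacing carbamoyl with cyano does. On this limited evidence, no step beyond the scatter is expected in this assay, and no direction is favoured. The estimated step is a 1.1-fold lower number from compound 2 to compound 3 (0.04 log units; within the scatter). Compound 3 is expected at 35 nM, with an estimated range of 10 nM to 120 nM.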

Compound 3, concentration for half-maximal effect: > 15 nM
Compound 3 was reported as a limit (the forecaster's own chance of this, stated with the estimate: 3%); the middle value is on the limit's open side.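

In this assay compound 3 gives > 15 nM, which is a limit and not a number, so neither step to compound 3, from compound 1 or from compound 2, can be read. The compounds shown leave open whether cyano in place of carbamoyl shifts the number in this assay, and in which direction.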